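Ester Chain Swap on an Adenine Cytotoxicity Series

The source may hold more compounds than are shown below. What is called first, only, known or untested is meant among the compounds shown, and "the series" means these compounds.

Compound 1 `Nc1ncnc2c1ncn2CC(O)C(=O)OC1CCCCC1` carries a cyclohexyl ester, and in a functional assay on PRK cells (Oryctolagus cuniculus) for cytotoxicity (a lower number here means that less compound is tolerated, a higher number that more compound is tolerated), compound 1 gives 100 ug/mL. Its open-chain counterpart, compound 2 `CCCCCOC(=O)C(O)Cn1cnc2c(N)ncnc21`, gives 200 ug/mL in this assay. The only measured step in the set, a 2.0-fold higher number from compound 1 to compound 2 (0.30 log units; within the scatter), places compound 2 at the top of the two numbers shown, but the gap lies within the scatter, so the two compounds cannot really be set apart by this assay.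

Compound 3 `CCC(C)OC(=O)C(O)Cn1cnc2c(N)ncnc21` is the next variation on the same oxygen: sec-butyl in place of pentyl on an oxygen next to a carbonyl group. For the measured compounds named here, the one step that bears on it is the earlier exchange of one alkyl group for another at the same place, a 2.0-fold higher number from compound 1 to compound 2 (0.30 log units; within the scatter), which produced no movement beyond the scatter. On that basis the change from pentyl to sec-butyl is expected to leave the tolerated concentration essentially where it stands, with no change at the digits printed from compound 2 to compound 3 (within the scatter) as the expected step. Compound 3 is therefore estimated at 200 ug/mL, with a likely range from 100 ug/mL to 400 ug/mL.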

Compound 3, minimum cytotoxic concentration: > 400 ug/mL
Compound 3 ended at the assay's limit; the forecaster's own chance of this, stated with the estimate: 15%; at least 2.0-fold (0.30 log units) between middle value and limit.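

Compound 3 reads as a limit of the assay rather than as a number: the limit of > 400 ug/mL in this assay, at which 1 of the 3 values shown sits. The exchange of cyclohexyl for sec-butyl gives an at least 4.0-fold higher number from compound 1 to compound 3 (0.60 log units; beyond the scatter), so a change on an oxygen next to a carbonyl group can move the tolerated concentration beyond the scatter, which the earlier pair did not show. From the compounds shown here alone, the exchange of pentyl for sec-butyl gives an at least 2.0-fold higher number from compound 2 to compound 3 (0.30 log units; that floor lies within the scatter), so this step alone does not set those two esters apart, and its true size remains unknown.

The compounds shown leave open whether an unbranched butyl or an isopropyl ester would also reach the limit, and so whether chain length or branching goes with the reading, since pentyl and sec-butyl differ in both. Also open, going by these compounds, are how a carboxylic acid at this place would read in this assay and how far beyond the limit the true value of compound 3 lies.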